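Truncating the ketone chain in a glutamate receptor modulator series

The source may report more compounds than this note shows. Statements on the series, on what has been measured and on what is new or still open speak of the compounds shown alone.

Measured compounds:
compound 1, `Cc1c(OCCCCOc2ccccc2C(=O)O)ccc(C(=O)CC2CCCC2)c1O`, 335 nM;
compound 2, `CCCC(=O)c1ccc(OCCCCOc2cccc(C(=O)O)c2C)c(C)c1O`, 52 nM;
compound 3, `Cc1cc(C(=O)O)ccc1OCCCCOc1ccc(C(=O)CC2CCCC2)c(O)c1C`, 608 nM.

In an assay on HEK293 cells for positive allosteric modulation of metabotropic glutamate receptor 2 (Rattus norvegicus), read by thallium flux, with a stated time of 2.5 min (on this read-out lower numbers stand for an effect already at smaller amounts and higher numbers for an effect only at larger amounts of compound), compound 2 gives the lowest of the three numbers; compound 1 and compound 3 both sit well beyond the scatter above it. Compound 4, `CC(=O)c1ccc(OCCCCOc2cccc(C(=O)O)c2C)c(C)c1O`, differs from compound 2 by hydrogen in place of ethyl on a saturated chain carbon bound to a carbonyl carbon. For the measured compounds named here, the only single-point step measured, a 1.8-fold higher number from compound 1 to compound 3 (0.26 log units; within the scatter), concerns the far aryl end and says nothing about the ketone chain. Going by the values given here, no measured pair isolates the acyl change, so compound 4 is judged with wide bounds; a modest loss is expected, a 3.8-fold higher number from compound 2 to compound 4 (0.59 log units; beyond the scatter). Compound 4 is therefore estimated at 200 nM, between 60 nM and 700 nM.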

Compound 4, half-maximal effective concentration: 200 nM
The estimate for compound 4 equals the measured number at the digits printed; the measured number falls inside the stated range.
By their numbers in this assay, from the lowest: compound 2; then compounds 4, 1 and 3 (each within the scatter of the next, the first and the last beyond it).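

A change in the ketone chain now has a measured step. The earlier step at the far aryl end could not show one. In this assay, cutting propyl to methyl on the carbonyl, with nothing else changed, gives a 3.8-fold higher number from compound 2 to compound 4 (0.59 log units; beyond the scatter), so the ethyl lost from the saturated chain carbon counts at this place. Nothing available explains why this change has that effect.

From the compounds shown here alone, it remains open where an ethyl chain on the same carbonyl would fall, and whether a longer pentyl chain would give a lower or a higher number than propyl.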